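Solubility notes on the shared core: compounds 1, 2, 3

A few compounds are considered here, and "the series" means these few. Any claim that something is new, unique, unknown or untested is made for them only; others in the source may bear on it.

Measured so far:
compound 1 `CC(=O)N1CCC(c2nc(NCc3cccnc3)ncc2-c2cc(C)no2)CC1` — 238000 nM
compound 2 `Cc1cc(-c2cnc(NCc3cccnc3)nc2-c2ccc(C)s2)on1` — 1000 nM

In a physicochemical assay for solubility, with a stated time of 24 h, at pH 3 (a higher number here means a more soluble compound, a lower number a less soluble compound), compound 1 gives 238000 nM, the highest of the two numbers; the nearest is compound 2, a 240-fold lower number from compound 1 to compound 2 (2.38 log units; beyond the scatter). That step concerns a different place on the core. Compound 3 `CC(=O)N1CCC(c2nc(NC(C)C)ncc2-c2cc(C)no2)CC1` carries isopropyl in place of (pyridin-3-yl)methyl on a nitrogen on an aromatic ring. Among the measured compounds shown here, no measured step touches this nitrogen, so the size of the change is not anchored by data. Taking compound 1 as the only reference, a lower number is expected, but with a wide range.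

For compound 3 the estimate in this assay is 80000 nM (range 15000 nM to 300000 nM), an expected step of a 3.0-fold lower number from compound 1 to compound 3 (0.47 log units; beyond the scatter).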

Compound 3, solubility: 224000 nM
The estimate for compound 3 lay 2.8-fold (0.45 log units) below the measured number, and the stated range covers the measured number.
By their numbers in this assay, from the lowest: compound 2; then compounds 3 and 1 (each within the scatter of the next).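

In this assay, among the compounds shown here, the one step on this nitrogen is a 1.1-fold lower number from compound 1 to compound 3 (0.03 log units; within the scatter), so at this position on the shared core isopropyl and (pyridin-3-yl)methyl cannot be told apart. The six-membered aromatic ring of compound 1, absent from compound 3, thus makes no readable difference in this pair. Going by these compounds, whether an amine, a carboxylic acid or a longer chain on this nitrogen would also stay within the scatter remains open, as does whether the same holds with 5-methylthiophen-2-yl on the core. No measurement at hand speaks to why the two groups read alike.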